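The source may report more compounds than this note shows. Statements on the series, on what has been measured and on what is new or still open speak of the compounds shown alone.

In a functional assay on HCT-116 cells (Homo sapiens) for antiproliferative activity, read by MTT assay, with a stated time of 24 h (a higher number here means a weaker inhibitor, a lower number a stronger inhibitor), compound 1 `C=CCOc1ccc2c(=O)c(-c3cc(OC)c(OC)cc3OC)coc2c1` gives 6600 nM, compound 2 `COc1cc(OC)c(-c2coc3cc(OCc4ccccc4F)ccc3c2=O)cc1OC` gives 2900 nM and compound 3 `COc1cc(OC)c(-c2coc3cc(OCc4ccc(Br)cc4)ccc3c2=O)cc1OC` gives 1980 nM. Compound 3 thus stands within the scatter of compound 2, as a 1.5-fold lower number from compound 2 to compound 3 (0.17 log units; within the scatter) shows, and well clear of compound 1, as a 3.3-fold lower number from compound 1 to compound 3 (0.52 log units; beyond the scatter) shows. Compound 4 `COc1cc(OC)c(-c2coc3cc(OCc4cccc(Cl)c4)ccc3c2=O)cc1OC` keeps the shared core and places 3-chlorophenyl in place of 4-bromophenyl on a saturated chain carbon bound to an oxygen on an aromatic ring. The modest steps of a 2.3-fold lower number from compound 1 to compound 2 (0.36 log units; beyond the scatter) and a 3.3-fold lower number from compound 1 to compound 3 (0.52 log units; beyond the scatter) both replace vinyl, so they bear on this change only loosely. Within the data shown here, the closest precedent is the exchange of one substituted phenyl for another, a 1.5-fold lower number from compound 2 to compound 3 (0.17 log units; within the scatter), which stayed within the scatter. A similar exchange is therefore expected to produce no step beyond the scatter, and the estimated change is a 1.2-fold higher number from compound 3 to compound 4 (0.07 log units; within the scatter). Compound 4 is estimated at 2300 nM, with an expected range of 1100 nM to 4800 nM.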

Compound 4, half-maximal inhibitory concentration: 1330 nM
The estimate for compound 4 lay 1.7-fold (0.24 log units) above the measured number; the range from low to high includes it.
By their numbers in this assay, from the lowest: compounds 4, 3 and 2 (each within the scatter of the next, the first and the last beyond it); then compound 1.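

In this assay, a second exchange of one substituted phenyl for another, here 3-chlorophenyl in place of 4-bromophenyl, stays within the scatter at a 1.5-fold lower number from compound 3 to compound 4 (0.17 log units; within the scatter), so compound 3 and compound 4 cannot be told apart. The substituted phenyls are not all equivalent at this position, however: a 2.2-fold lower number from compound 2 to compound 4 (0.34 log units; beyond the scatter) lies beyond the scatter, though it is modest, and a 5.0-fold lower number from compound 1 to compound 4 (0.70 log units; beyond the scatter) is the largest step in the set. No available evidence bears on what lies behind these differences.

Because chlorine and bromine also sit at different ring positions in compound 4 and compound 3, the effect of the halogen cannot be separated from that of its position. The compounds shown also leave open how a phenyl bearing a methoxy group or a nitrile, or a chain ending in an amine, would behave here.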